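This account rests on a few compounds, and the source may have more. Where it says the series, first, only, none or still open, it means among the compounds named here.

Measured so far in a functional assay on HCT-15 cells (Homo sapiens) for inhibition, read by sulforhodamine B assay, with a stated time of 48 h; on this read-out higher numbers stand for weaker inhibition of growth and lower numbers for stronger inhibition of growth:
compound 1 `COc1cc(-c2cc(/C=C/C(=O)c3ccc(N)cc3)[nH]n2)cc(OC)c1OC` gives 1370 nM
compound 2 `COc1cc(-c2cc(/C=C/C(=O)c3ccc(Cl)c(Cl)c3)[nH]n2)cc(OC)c1OC` gives 4290 nM
compound 3 `COc1ccc(C(=O)/C=C/c2cc(-c3cc(OC)c(OC)c(OC)c3)n[nH]2)cc1OC` gives 1270 nM

Compound 3 has the lowest of the three numbers in this assay, but only compound 2 is separated from it beyond the scatter: a 3.4-fold lower number from compound 2 to compound 3 (0.53 log units; beyond the scatter). Against compound 1 the gap is within the scatter: a 1.1-fold lower number from compound 1 to compound 3 (0.03 log units; within the scatter). The remaining step, a 3.1-fold higher number from compound 1 to compound 2 (0.50 log units; beyond the scatter), is the other modest one in the set.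

Compound 4 `COc1ccc(C(=O)/C=C/c2cc(-c3cc(OC)c(OC)c(OC)c3)n[nH]2)cc1` differs from compound 3 on the six-membered aromatic ring of carbon only that sits on the carbonyl carbon: hydrogen in place of methoxy on an aromatic carbon. Among the compounds with values here, none of the measured steps removes a single methoxy from that ring; each exchanges the whole group on the carbonyl carbon. What they show is that this position moves the assay by modest amounts at most, and that the 4-aminophenyl and 3,4-dimethoxyphenyl analogues sit within the scatter of each other. Removing one methoxy is a smaller change than any of those exchanges. For compound 4 the expected step is therefore a 1.2-fold higher number from compound 3 to compound 4 (0.07 log units; within the scatter), none beyond the scatter. Compound 4 is estimated at 1500 nM, with a range of 600 nM to 4000 nM.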

Compound 4, concentration for 50% growth inhibition: 1580 nM
Compound 4: middle estimate off by 1.1-fold (0.02 log units), on the low side; the measured number falls inside the stated range.
By their numbers in this assay, from the lowest: compounds 3, 1 and 4 (each within the scatter of the next); then compound 2.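

In this assay, within the data shown here, this is the first direct reading of a single methoxy on this ring: taking away the methoxy that sits ortho to the remaining methoxy group leaves the number within the scatter (a 1.2-fold higher number from compound 3 to compound 4 (0.09 log units; within the scatter)), so 3,4-dimethoxyphenyl and 4-methoxyphenyl cannot be told apart here. Methoxy and amino on the ring also cannot be told apart (a 1.2-fold higher number from compound 1 to compound 4 (0.06 log units; within the scatter)), so compounds 1, 3 and 4 form one band within the scatter of each other, whether the ring carries amino, one methoxy or two. Compound 2 alone stands outside that band, and the step to the 4-methoxyphenyl analogue is a modest one (a 2.7-fold lower number from compound 2 to compound 4 (0.43 log units; beyond the scatter)), while nothing available accounts for any of these steps.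

Still open, from the compounds shown here alone, is whether phenyl with no group on it, a single chlorine, an ethoxy group or a carboxylic acid on this ring would stay in the band or move out with compound 2. The shared core is constant across all four compounds, so these steps say nothing about changes elsewhere in it.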